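Ester series on a shared core: naphthyl to tert-butylphenyl

The source may hold more compounds than are shown below. What is called first, only, known or untested is meant among the compounds shown, and "the series" means these compounds.

Three esters of a shared core have been run in a functional assay on MCF7 cells (Homo sapiens) for antiproliferative activity, read by MTT assay, with a stated time of 72 h, tested at 200 uM; on this read-out higher numbers stand for a weaker effect at the one concentration tested and lower numbers for a stronger effect. Compound 1 `COC(C(=O)OC(C)Cn1cnc2c1c(=O)n(C)c(=O)n2C)c1cccc2ccccc12` gives 76.9% in this assay, the second highest of the three numbers. Compound 3 `Cc1ccc(C(=O)CC(=O)OC(C)Cn2cnc3c2c(=O)n(C)c(=O)n3C)cc1` gives 82.7%, a number within the scatter of compound 1. Compound 2 `CC(Cn1cnc2c1c(=O)n(C)c(=O)n2C)OC(=O)Sc1ccccc1` gives 43.1%, a number beyond the scatter and lower than compound 1. Among the measured compounds shown here, no pair of measured compounds differs in one place, so the series offers no direct guide for a single exchange.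

Compound 4 `COC(C(=O)OC(C)Cn1cnc2c1c(=O)n(C)c(=O)n2C)c1ccc(C(C)(C)C)cc1` is not yet measured. It differs from compound 1 by 4-(tert-butyl)phenyl in place of naphthalen-1-yl on a saturated chain carbon bound to a carbonyl carbon and an oxygen on a saturated carbon. What leaves and what enters are alike in what is counted, so no step beyond the scatter is expected in this assay; the expected step is a number 1.9 percentage points lower from compound 1 to compound 4 (within the scatter). Compound 4 is estimated at 75%, with a range from 55% to 92%.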

Compound 4, a percentage reported as activity, at one concentration (the size of the read-out at that concentration, not a potency): 35%
For compound 4 the middle estimate is 40 percentage points above the measured one, outside the stated range (below it).
By their numbers in this assay, from the lowest: compounds 4 and 2 (each within the scatter of the next); then compounds 1 and 3 (each within the scatter of the next).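

In this assay the saturated chain carbon bound to a carbonyl carbon and an oxygen on a saturated carbon proves sensitive to the group it carries: the exchange of naphthalen-1-yl for 4-(tert-butyl)phenyl gives a number 41.9 percentage points lower from compound 1 to compound 4 (beyond the scatter), a stronger effect at the one concentration tested. Both groups count the same heavy atoms, so that count alone does not make them interchangeable here. No measurement at hand explains this step.

Going by these compounds, it remains open whether the step follows the tert-butyl group or the single aromatic ring. Also open, on these data alone, is how a plain phenyl, or a phenyl carrying an amine or a carboxylic acid, would read at this position.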